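The source may report more compounds than this note shows. Statements on the series, on what has been measured and on what is new or still open speak of the compounds shown alone.

Measured compounds and values:

- Compound 1 `CO[C@]1(C(=O)N2CC[C@](c3ccc(C(F)(C(F)(F)F)C(F)(F)F)cc3)(S(=O)(=O)c3ccc(F)cc3)C2)CC[C@H](C(=O)O)CC1` — 95%
- Compound 2 `O=C(C1CCS(=O)(=O)C1)N1CC[C@](c2ccc(C(F)(C(F)(F)F)C(F)(F)F)cc2)(S(=O)(=O)c2ccc(F)cc2)C1` — 78%; 96% (2 entries)
- Compound 3 `CC1(C(=O)N2CC[C@](c3ccc(C(F)(C(F)(F)F)C(F)(F)F)cc3)(S(=O)(=O)c3ccc(F)cc3)C2)CCS(=O)(=O)CC1` — "not determined" (no result reported)

Going by the values given here, compound 1 gives the only single number in an ADME assay on microsomes from liver (Mus musculus) for metabolic stability, with a stated time of 10 min (on this read-out higher numbers stand for a more stable compound and lower numbers for a less stable compound), namely 95%; compound 2 brings two further entries, 78%; 96% (2 entries), and compound 3 contributes nothing that can be placed. Within this assay compound 1 therefore stands at the high end of what has been recorded, but the spread of compound 2, seen in the several entries of compound 2 in this assay, 78%; 96% (2 entries), shows how widely repeat entries of the same compound can fall, so no ranking of compound 1 against compound 2 is claimed.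

The unmeasured compound 4 `O=C(N1CC[C@](c2ccc(C(F)(C(F)(F)F)C(F)(F)F)cc2)(S(=O)(=O)c2ccc(F)cc2)C1)C1(O)CCS(=O)(=O)CC1` is reached from compound 1 by one change on a carbonyl carbon: 4-hydroxy-1,1-dioxothian-4-yl in place of 4-carboxy-1-methoxycyclohexyl on a carbonyl carbon. The 4-carboxy-1-methoxycyclohexyl group leaves and the 4-hydroxy-1,1-dioxothian-4-yl group enters; the rest of the shared core is untouched.

Among the compounds with values here, no step between measured compounds is available to anchor the size of this change. Compound 2, which also carries a sulfone-bearing ring on that carbonyl carbon, gives 78%; 96% (2 entries) and stays in the same broad region as compound 1. The step from compound 1 to compound 4 is therefore expected to be small, a modest drop at most, a number 7 percentage points lower from compound 1 to compound 4 (within the scatter), with a fair chance of no change beyond the scatter. For compound 4 the expected value in this assay is 88%, with a range from 74% to 98%.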

Compound 4, percent of the compound remaining: 90%
Estimate against measurement, compound 4: 2 percentage points below; measured number inside the range.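

Going by these compounds alone, exchanging 4-carboxy-1-methoxycyclohexyl for 4-hydroxy-1,1-dioxothian-4-yl on a carbonyl carbon whose other neighbours are an amide-type nitrogen in a ring gives the first readable step at this position in this assay: a number 5 percentage points lower from compound 1 to compound 4 (within the scatter). This read-out therefore does not separate the two groups, and a sulfur-containing ring with a hydroxy group can take the place of a carbon-only ring with a carboxy and a methoxy group without a step beyond the scatter. Small differences at this position remain hard to read, as the repeat entries of one related compound show: the several entries of compound 2 in this assay, 78%; 96% (2 entries)

As far as these compounds go, it remains open how a group such as a primary amine or a plain cyclohexyl would read on this carbonyl carbon in this assay. The compounds shown also give no step for any change elsewhere on the shared core.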